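Swapping the Five-Membered Aryl Group on the Shared Core

The compounds below may be only part of what the source reports. "The series", "measured", "known", "first", "only" and "open" are said of these compounds alone.

Measured compounds:
compound 1 `COc1ncnc2c1c(-c1ccsc1)cn2[C@@H]1O[C@H](CO)[C@@H](O)[C@H]1O` — 3350 nM
compound 2 `Cc1ncnc2c1c(-c1ccsc1)cn2[C@@H]1O[C@H](CO)[C@@H](O)[C@H]1O` — 14300 nM

In a functional assay on HeLa S3 cells (Homo sapiens) for antiproliferative activity, read by XTT assay, with a stated time of 72 h (a lower number here means a stronger inhibitor, a higher number a weaker inhibitor), compound 1 gives 3350 nM, the lowest of the two numbers; its nearest neighbour is compound 2 with 14300 nM. Among the compounds with values here, the one measured step, a 4.3-fold higher number from compound 1 to compound 2 (0.63 log units; beyond the scatter), alters the six-membered ring of the core and leaves the thiophen-3-yl group untouched.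

Compound 3 `COc1ncnc2c1c(-c1cc3ccccc3o1)cn2[C@@H]1O[C@H](CO)[C@@H](O)[C@H]1O` keeps the methoxy of compound 1 and changes the aryl group instead: 1-benzofuran-2-yl in place of thiophen-3-yl on an aromatic carbon. Within the data shown here, no measured step touches this position, so the size and direction of the change in this assay cannot be read from compound 1 and compound 2, and the expectation must stay loose. Compound 3 is therefore expected to land near compound 1, with a step of a 1.7-fold lower number from compound 1 to compound 3 (0.22 log units; within the scatter) in this assay as the central guess, and an estimated value of 2000 nM within a wide range from 300 nM to 15000 nM.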

Compound 3, half-maximal inhibitory concentration: 9240 nM
The estimate for compound 3 lay 4.6-fold (0.66 log units) below the measured number; the range from low to high includes it.
By their numbers in this assay, from the lowest: compound 1; then compounds 3 and 2 (each within the scatter of the next).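

This gives the aryl position its first measured step: in this assay, 1-benzofuran-2-yl in place of thiophen-3-yl gives a 2.8-fold higher number from compound 1 to compound 3 (0.44 log units; beyond the scatter). The number therefore responds to the aryl group on this aromatic carbon, and here the larger group, with its added six-membered aromatic ring of carbon only, does not improve on thiophen-3-yl. Nothing available explains this step.

The change adds that ring and also puts oxygen in place of sulfur, so the compounds shown cannot separate the two, and a furan-2-yl or a phenyl group at this position would be needed to tell them apart. On these data alone, it also remains open whether the step would carry over to the methyl-bearing core of compound 2, or how an aminomethyl group on the aryl ring would fare.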